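The compounds below may be only part of what the source reports. "The series", "measured", "known", "first", "only" and "open" are said of these compounds alone.

Measured so far in an assay on HEK293 cells for positive allosteric modulation of metabotropic glutamate receptor 5 (Homo sapiens), read by FLIPR, with a stated time of 1 h; a higher number here means that more compound is needed for the effect, a lower number that less compound is needed:
compound 1 `N#Cc1cccc(C(=O)N2CCc3nc(C#Cc4ccccc4)sc3C2)c1`: 71 nM
compound 2 `Cc1cccc(C(=O)N2CCc3nc(C#Cc4ccccc4)sc3C2)n1`: 160 nM

For the measured compounds named here, compound 2 stands highest of the two numbers in hand; its only neighbour is compound 1, and the single step in hand, a 2.3-fold higher number from compound 1 to compound 2 (0.35 log units; beyond the scatter), runs between them, a swap of one six-membered aromatic group for another on the carbonyl carbon.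

Compound 3 `O=C(N1CCC(F)CC1)N1CCc2nc(C#Cc3ccccc3)sc2C1` is still to be measured in this assay. It differs from compound 2 in one place: 4-fluoropiperidin-1-yl in place of 6-methylpyridin-2-yl on a carbonyl carbon. Going by the values given here, no measured step bears directly on this change. The step from compound 1 to compound 2 kept an aromatic ring on the carbonyl carbon and moved the number only modestly; here the aromatic ring gives way to a six-membered non-aromatic ring and the hydrogen-bond acceptor count drops, a larger departure than anything yet measured. The expectation is therefore uncertain and the range is set wide, with the step of a 2.5-fold higher number from compound 2 to compound 3 (0.40 log units; beyond the scatter) expected to go toward a higher number, beyond the scatter. Compound 3 is estimated at 400 nM, in a range from 100 nM to 2500 nM.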

Compound 3, half-maximal effective concentration: 74 nM
For compound 3 the middle estimate is 5.4-fold (0.73 log units) above the measured one; the whole stated range lies above it.
By their numbers in this assay, from the lowest: compounds 1 and 3 (each within the scatter of the next); then compound 2.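

On the carbonyl carbon whose other neighbour is the amide-type nitrogen in a ring, activity in this assay does not depend on an aromatic ring, a point that the two aromatic groups compared earlier could not settle. The change to 4-fluoropiperidin-1-yl gives a 2.2-fold lower number from compound 2 to compound 3 (0.33 log units; beyond the scatter), so in this pair the six-membered non-aromatic ring without a hydrogen-bond acceptor does better than 6-methylpyridin-2-yl, while a 1.0-fold higher number from compound 1 to compound 3 (0.02 log units; within the scatter) leaves 4-fluoropiperidin-1-yl and 3-cyanophenyl indistinguishable. No measurement in hand accounts for either step.

Going by these compounds, the share of the fluorine in this result stays open, and a plain piperidin-1-yl or a morpholin-4-yl group on the same carbonyl carbon would separate the contribution of the fluorine from that of the saturated ring. On these data alone, it is also open whether a ring is needed at all at this position, a question that an open-chain amine such as diethylamino on the carbonyl carbon would address.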